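Propyl for isopropyl on a short series

The compounds below may be only part of what the source reports. "The series", "measured", "known", "first", "only" and "open" are said of these compounds alone.

- Compound 1 `CCc1ccc(-c2nc3c(c(C)nn3-c3ccccc3)c(-c3ccccc3O)c2C#N)cc1`: > 20000 nM, a limit.
- Compound 2 `COc1cccc(-c2nc3c(c(C)nn3-c3ccccc3)c(-c3ccccc3O)c2C#N)c1`: > 23000 nM, a limit.
- Compound 3 `Cc1nn(-c2ccccc2)c2nc(-c3ccc(C(C)C)cc3)c(C#N)c(-c3ccccc3O)c12`: 22600 nM.

Going by the values given here, in an ADME assay on BJ cells (Homo sapiens) for cytotoxicity, with a stated time of 72 h (a lower number here means that less compound is needed, a higher number that more compound is needed for the effect), compound 3 gives 22600 nM, the only true number here. The other two values are limits. Compound 4 `CCCc1ccc(-c2nc3c(c(C)nn3-c3ccccc3)c(-c3ccccc3O)c2C#N)cc1` differs from compound 3 as follows: propyl in place of isopropyl on an aromatic carbon. That is propyl in place of isopropyl on an aromatic carbon, para to a large group. Among the compounds with values here, two measured steps bear on this, and neither gives a usable size: a step that the limit leaves unreadable from compound 1 to compound 3, the nearest change in the alkyl group, and an at least 1.0-fold lower number from compound 2 to compound 3 (0.00 log units; that floor lies within the scatter). No step beyond the scatter is therefore expected, and the expected step is a 1.0-fold higher number from compound 3 to compound 4 (0.01 log units; within the scatter). The estimate for compound 4 is 23000 nM, with an expected range of 13000 nM to 40000 nM.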

Compound 4, half-maximal effective concentration: 22500 nM
Estimate against measurement, compound 4: 1.0-fold (0.01 log units) above, within the range that was stated.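

Propyl in place of isopropyl gives a 1.0-fold lower number from compound 3 to compound 4 (0.00 log units; within the scatter) in this assay, the first step in the series that rests on two true numbers. At this place, para to a large group, the two chains therefore read alike. 4-Propylphenyl in place of 3-methoxyphenyl gives an at least 1.0-fold lower number from compound 2 to compound 4 (0.00 log units; that floor lies within the scatter), a floor only, and the step from compound 1 cannot be read, as compound 1 carries a limit: the limit of > 20000 nM in this assay, at which 1 of the 4 values shown sits.

As far as these compounds go, whether a longer chain such as butyl at this place would take the value beyond the scatter stays open. So does the effect of an amine or a carboxylic acid there.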